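Cyano to 4-Bromophenyl: An Expected Cytotoxicity Shift

The source may hold more compounds than are shown below. What is called first, only, known or untested is meant among the compounds shown, and "the series" means these compounds.

Compound 1, `CCC1(Cc2ccccc2)OS(=O)(=O)C=C1OCC#N`: > 200000 nM
Compound 2, `CCC1(Cc2ccccc2)OS(=O)(=O)C=C1OCCCCCCc1ccccc1`: < 200000 nM

Of the compounds shown here, two have been measured in an ADME assay on HEL cells (Homo sapiens) for cytotoxicity, with a stated time of 3 days; on this read-out lower numbers stand for higher toxicity in this test and higher numbers for lower toxicity in this test. In this assay compound 1 gives > 200000 nM, which is a limit of the assay and not a number; compound 1 stands at the limit of > 200000 nM in this assay, at which 1 of the 2 values shown sits. Compound 2 gives < 200000 nM in this assay, likewise a limit, at the limit of < 200000 nM in this assay, at which 1 of the 2 values shown sits. Going by the values given here, no step between measured compounds is known. Compound 3 `CCC1(Cc2ccccc2)OS(=O)(=O)C=C1OCc1ccc(Br)cc1` has not yet been measured in this assay. It differs from compound 1 by 4-bromophenyl in place of cyano on a saturated chain carbon bound to an oxygen on an unsaturated carbon. The step in this assay is expected to be an at least 2.0-fold lower number from compound 1 to compound 3 (0.30 log units; that floor lies within the scatter), toward higher toxicity. Compound 3 is estimated at 100000 nM, between 30000 nM and 300000 nM.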

Compound 3, half-maximal cytotoxic concentration: 171000 nM
Beside the measured number, compound 3's estimate is 1.7-fold (0.23 log units) below it, and the stated range covers the measured number.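

In this assay, going by these compounds alone, compound 3 gives a number and not a limit, so 4-bromophenyl on a saturated chain carbon bound to an oxygen on an unsaturated carbon yields the first true value at this place. The change reads as an at least 1.1-fold lower number from compound 1 to compound 3 (0.06 log units; that floor lies within the scatter), which shows no shift beyond the usual scatter. The step remains only a floor because the value for compound 1 is a limit: the limit of > 200000 nM in this assay, at which 1 of the 3 values shown sits.

On these data alone, how far compound 1 truly lies from compound 3 stays open. So does what an amine or a carboxylic acid would give at this place.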